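A few compounds are considered here, and "the series" means these few. Any claim that something is new, unique, unknown or untested is made for them only; others in the source may bear on it.

Compound 1 `Cc1nc(N2CCN(S(C)(=O)=O)CC2)nc2ccc(NC(=O)COc3ccc(Cl)cc3)cc12`, compound 2 `Cc1nc(N2CCN(C(=O)C3CC3)CC2)nc2ccc(NC(=O)COc3ccc(OC(F)(F)F)cc3)cc12` and compound 3 `CCN1CCN(c2nc(C)c3cc(NC(=O)COc4ccc(Cl)cc4)ccc3n2)CC1` share one core and differ at the group carried on it. In an assay on CHO-K1 cells for displacement of a labelled ligand from melanin-concentrating hormone receptor 1 (Homo sapiens), with a stated time of 2 h (on this read-out higher numbers stand for weaker inhibition and lower numbers for stronger inhibition), compound 1 gives only the assay limit > 10000 nM. Compound 3 gives 690 nM and compound 2 gives 49 nM, the lowest number of the two measured values, with compound 3 as its nearest neighbour. Among the compounds with values here, the one measured step, an at least 14-fold lower number from compound 1 to compound 3 (1.16 log units; beyond the scatter), is large, and compound 1 sits at the limit described by the limit of > 10000 nM in this assay, at which 1 of the 3 values shown sits.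

Compound 4 `Cc1nc(N2CCC(O)(C3CC3)CC2)nc2ccc(NC(=O)COc3ccc(OC(F)(F)F)cc3)cc12` has not been measured. It differs from compound 2 in one place: 4-cyclopropyl-4-hydroxypiperidin-1-yl in place of 4-(cyclopropylcarbonyl)piperazin-1-yl on an aromatic carbon. Within the data shown here, no measured step changes this part of the ring in the same way, and the only comparison available is the large move seen from compound 1 to compound 3 at the same region, so a change in this assay of some size is expected, in a direction that cannot be settled. Compound 4 is therefore estimated at 120 nM, between 25 nM and 600 nM, an expected step of a 2.4-fold higher number from compound 2 to compound 4 (0.39 log units; beyond the scatter).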

Compound 4, half-maximal inhibitory concentration: 101 nM
For compound 4 the middle estimate is 1.2-fold (0.07 log units) above the measured one, and the stated range covers the measured number.
By their numbers in this assay, from the lowest: compound 2; then compound 4; then compound 3. At a limit, above all of these: compound 1.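

At this position, on an aromatic carbon between two ring nitrogen atoms, the swap of 4-(cyclopropylcarbonyl)piperazin-1-yl for 4-cyclopropyl-4-hydroxypiperidin-1-yl gives a 2.1-fold higher number from compound 2 to compound 4 (0.31 log units; beyond the scatter) in this assay. The earlier compounds shown here did not show that this group can lose its carbonyl and a ring nitrogen and gain a hydrogen-bond donor at a modest cost, with the cyclopropyl ring kept. Nothing shown here accounts for the size of this step.

The compounds shown leave open whether the new hydroxy group or the loss of the carbonyl drives the step, as both change at once in this pair. They also leave open how an amine or a carboxylic acid in place of that hydroxy group, or a longer chain in place of the cyclopropyl ring, would read in this assay.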